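The source may report more compounds than this note shows. Statements on the series, on what has been measured and on what is new or still open speak of the compounds shown alone.

Series notes on an assay on K177 cells for activation of Neuronal acetylcholine receptor; alpha4/beta2 (Homo sapiens); on this read-out higher numbers stand for an effect only at larger amounts of compound and lower numbers for an effect already at smaller amounts. Compound 1 `CN1CCC[C@H]1COc1cncc(Br)c1` gives 5950 nM in this assay, and compound 2 `Cc1cncc(OC[C@@H]2CCCN2C)c1` gives 2300 nM. The change of methyl in place of bromo on an aromatic carbon yields a 2.6-fold lower number from compound 1 to compound 2 (0.41 log units; beyond the scatter). Going by the values given here, compound 2 therefore holds the lowest of the two numbers so far, with compound 1 as its only neighbour.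

Compound 3 `CCc1cncc(OC[C@@H]2CCCN2C)c1` is not yet measured. It differs from compound 2 by methyl in place of hydrogen on a saturated chain carbon bound to an aromatic carbon, which cut one bond further out reads methyl to ethyl. Among the compounds with values here, only one measured step touches this part of the molecule, namely a 2.6-fold lower number from compound 1 to compound 2 (0.41 log units; beyond the scatter), and it swaps a halogen for a carbon group rather than extending a chain, so it offers little direct guidance. The expectation is that compound 3 sits within the scatter of compound 2 or slightly higher, with a step of a 1.5-fold higher number from compound 2 to compound 3 (0.18 log units; within the scatter) estimated. The estimate for compound 3 in this assay is 3500 nM, with a range from 1400 nM to 9000 nM.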

Compound 3, half-maximal effective concentration: 1000 nM
Compound 3: the middle estimate sits 3.5-fold (0.54 log units) above what was measured, and the stated range ends above it.
By their numbers in this assay, from the lowest: compound 3; then compound 2; then compound 1.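

Methyl to ethyl gives a 2.3-fold lower number from compound 2 to compound 3 (0.36 log units; beyond the scatter) in this assay, so this place on the shared core still responds to a single added carbon on a saturated chain, which the earlier halogen-to-carbon swap could not show. Measured against bromo, ethyl gives a 6.0-fold lower number from compound 1 to compound 3 (0.77 log units; beyond the scatter), a larger step than a 2.6-fold lower number from compound 1 to compound 2 (0.41 log units; beyond the scatter), so the numbers in these three compounds fall in the order bromo, methyl, ethyl, with none of them going against that order. No measurement at hand accounts for this trend.

From the compounds shown here alone, whether a longer chain such as propyl extends the fall or reverses it remains open. Also open is whether a branched isopropyl or a methoxy at this place would follow ethyl, since a straight two-carbon chain is the largest group shown here.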